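The source may report more compounds than this note shows. Statements on the series, on what has been measured and on what is new or still open speak of the compounds shown alone.

In an ADME assay on Vero cells (Chlorocebus sabaeus) for cytotoxicity, read by MTT assay, with a stated time of 72 h (on this read-out lower numbers stand for higher toxicity in this test and higher numbers for lower toxicity in this test), compound 1 `CCOC(=O)CN1CCN(c2c(F)cc3c(=O)c(C(=O)O)cn(C4CC4)c3c2OC)CC1C` gives 1000 ug/mL and compound 2 `COc1c(N2CCN(C/C(C)=N/NC(C)=O)C(C)C2)c(F)cc2c(=O)c(C(=O)O)cn(C3CC3)c12` gives 707 ug/mL, so compound 2 stands level with compound 1 within the scatter. Compound 3 `COc1c(N2CCN(C/C(C)=N/Nc3ccccc3)C(C)C2)c(F)cc2c(=O)c(C(=O)O)cn(C3CC3)c12` differs from compound 2 as follows: phenyl in place of acetyl on an amine nitrogen. This puts phenyl in place of acetyl on an amine nitrogen, or acetamido to anilino when cut one bond further out. Among the compounds with values here, only one measured step bears on this, and only indirectly: a 1.4-fold lower number from compound 1 to compound 2 (0.15 log units; within the scatter), made at another place in the molecule and within the scatter. Within the data shown here, no measured compound carries the phenyl group, so the effect of this change has not been tested directly. A small shift towards a lower number is expected, not beyond the scatter, as a 1.6-fold lower number from compound 2 to compound 3 (0.20 log units; within the scatter). For compound 3 the estimated value is 450 ug/mL, with an expected range of 150 ug/mL to 1000 ug/mL.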

Compound 3, half-maximal cytotoxic concentration: 11.1 ug/mL
Compound 3: the middle estimate sits 41-fold (1.61 log units) above what was measured, and the stated range ends above it.
By their numbers in this assay, from the lowest: compound 3; then compounds 2 and 1 (each within the scatter of the next).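

In this assay, within the data shown here, phenyl in place of acetyl on an amine nitrogen whose other neighbour is a double-bonded nitrogen gives a 64-fold lower number from compound 2 to compound 3 (1.80 log units; beyond the scatter), the first step beyond the scatter, so the group at this position can strongly change the read-out. Against compound 1, the group of 10 heavy atoms with its six-membered aromatic ring gives a 90-fold lower number from compound 1 to compound 3 (1.95 log units; beyond the scatter), whereas the acetyl-bearing group gave only a 1.4-fold lower number from compound 1 to compound 2 (0.15 log units; within the scatter) at the same place, so the end of the chain decides the outcome among these compounds. No measurement on hand explains this drop.

On these data alone, whether the drop follows the aromatic ring itself or the loss of acetyl stays open; cyclohexyl or benzoyl on this amine nitrogen would separate the two. As far as these compounds go, how a chlorophenyl or a pyridyl group would read also remains unknown.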